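Shortening the butyl chain of compound 2

A few compounds are considered here, and "the series" means these few. Any claim that something is new, unique, unknown or untested is made for them only; others in the source may bear on it.

Measured so far in a functional assay for inhibition, with Rattus norvegicus as the target; a lower number here means a stronger inhibitor, a higher number a weaker inhibitor:
Compound 1 `CCOC(=O)c1c(CC)c(OC)c2ccccc2c1OC(C)=O` gives (3760 nM)
Compound 2 `CCCCc1c(CC)c(OC(C)=O)c2ccccc2c1OC` gives (1130 nM)

Compound 2 (1130 nM) has the lower of the two numbers, which makes it the stronger inhibitor of the pair, and its gap to compound 1 (3760 nM) lies beyond the usual scatter. These two compounds differ in more than one place, so their values do not show what any single change does.

Compound 3 `CCc1c(CC)c(OC(C)=O)c2ccccc2c1OC` has not yet been measured in this assay. It differs from compound 2 in one place, where the butyl chain is cut back to ethyl (hydrogen in place of ethyl on a saturated chain carbon, two bonds along the chain from an aromatic carbon). Put another way, hydrogen stands in place of ethyl on a saturated chain carbon, two bonds along the chain from an aromatic carbon.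

Among the compounds with values here, no measured pair shows a change of this kind, so the expectation is tentative. A modest rise in the number is expected, perhaps none beyond the scatter (a 1.6-fold higher number from compound 2 to compound 3 (0.20 log units; within the scatter)). For compound 3 the estimated value is 1800 nM, with an expected range from 600 nM to 5500 nM.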

Compound 3, half-maximal inhibitory concentration: 400 nM
Estimate against measurement, compound 3: 4.5-fold (0.65 log units) above; measured number below the stated range.
By their numbers in this assay, from the lowest: compound 3; then compound 2; then compound 1.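

Within the data shown here, compound 3 is the first compound that allows a single change to be read at this position. In this assay, cutting butyl back to ethyl gives a 2.8-fold lower number from compound 2 to compound 3 (0.45 log units; beyond the scatter), which shows that the full butyl chain is not required for inhibition at this position and that the shorter chain is the stronger of the two here. The same compound also isolates a change on an aromatic carbon: ethyl in place of ethoxycarbonyl gives a 9.4-fold lower number from compound 1 to compound 3 (0.97 log units; beyond the scatter), so compound 3 is the strongest inhibitor of the three, with both of its steps beyond the scatter.

With only butyl and ethyl compared at the chain position, the compounds shown do not tell whether the number would keep falling with methyl or would rise again with propyl. They also leave open how a carboxylic acid or a primary amide would compare with ethyl and ethoxycarbonyl on the aromatic carbon, and whether the acetate ester of the shared core matters to the result. The data at hand offer no measured explanation for either fall in the number.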